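This account rests on a few compounds, and the source may have more. Where it says the series, first, only, none or still open, it means among the compounds named here.

In an ADME assay on HEK293 cells (Homo sapiens) for antiproliferative activity, read by MTT assay, with a stated time of 48 h (a higher number here means a weaker inhibitor, a lower number a stronger inhibitor), compound 2 `O=C(/C=C/c1cn(S(=O)(=O)c2cccc([N+](=O)[O-])c2)c2ccccc12)c1ccncc1` stands at > 150000 nM and this is a limit of the assay, not a number. Compound 1 `Cc1ccc(S(=O)(=O)n2cc(/C=C/C(=O)c3ccncc3)c3ccccc32)cc1` sits at > 150000 nM which is likewise a limit. Compound 3 `COc1ccc(S(=O)(=O)n2cc(/C=C/C(=O)c3ccncc3)c3ccccc32)cc1` sits at > 150000 nM which is again a limit. The measured picture is thus the limit of > 150000 nM in this assay, at which 3 of the 3 values shown sit, and no true number is yet in hand for any of these compounds.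

Compound 4 `O=C(/C=C/c1cn(S(=O)(=O)c2ccc(Cl)cc2Cl)c2ccccc12)c1ccncc1` differs from compound 2 at a single place: 2,4-dichlorophenyl in place of 3-nitrophenyl on a sulfonyl sulfur and the rest of the molecule stays the same. In words, 2,4-dichlorophenyl stands in place of 3-nitrophenyl on a sulfonyl sulfur.

Among the measured compounds shown here, three measured steps bear on this change, since all of them alter the same group on the sulfonyl sulfur: a step that the two limits leave unreadable from compound 1 to compound 2 and a step that the two limits leave unreadable from compound 2 to compound 3 and also a step that the two limits leave unreadable from compound 1 to compound 3 and none of them has a size that can be read. With no measured size to go on, no step beyond the scatter is expected in this assay in either direction. The expected outcome is a number no higher from compound 2 to compound 4 (the limit leaves the size open) and it may well be only a limit. For compound 4 the estimated value is 150000 nM with an expected range from 50000 nM to 300000 nM in this estimate.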

Compound 4, half-maximal inhibitory concentration: > 150000 nM
Compound 4 gave a limit, no number (the forecaster's own chance of this, stated with the estimate: 70%); the middle value sits exactly at the limit.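

In this assay compound 4 gives > 150000 nM, which is a limit of the assay and not a number. No step from compound 1, compound 2 or compound 3 to compound 4 can be read, and the four compounds share one limit: the limit of > 150000 nM in this assay, at which 4 of the 4 values shown sit.

The compounds shown leave open whether changing the group on the sulfonyl sulfur alters the value at all.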